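The source may hold more compounds than are shown below. What is called first, only, known or untested is meant among the compounds shown, and "the series" means these compounds.

Measured compounds in a toxicity assay on the whole organism (J774 cells) for cytotoxicity, with Mus musculus as the target, read by MTT assay, with a stated time of 24 h, tested at 30 uM; on this read-out lower numbers stand for a stronger effect and higher numbers for a weaker effect at the one concentration tested:
- compound 1 `CCCCCCCCCO[C@@H]1[C@@H](N)[C@@H](OCC(O)CNCCN)O[C@H](CN)[C@H]1OCCCCCCCCC`: 53%
- compound 2 `CCCCCCCCCO[C@@H]1[C@@H](N)[C@@H](OC[C@@H](O)CN)O[C@H](CN)[C@H]1OCCCCCCCCC`: 7.2%
- compound 3 `C=CCO[C@H]1O[C@H](CN)[C@@H](OCCCc2ccc3ccccc3c2)[C@H](OCCCc2ccc3ccccc3c2)[C@H]1N`: 7%

Compound 1 stands highest of the three numbers in this assay; both other values lie beyond the scatter from it, and the values of compound 2 and compound 3 lie within the scatter of each other. Compound 4 `CCCCCCCCCO[C@@H]1[C@@H](N)[C@@H](O[C@H]2[C@H](O)[C@@H](O)[C@H](N)C[C@@H]2N)O[C@H](CN)[C@H]1OCCCCCCCCC` is not yet measured and differs from compound 1 at the oxygen on the saturated carbon of the shared core: 4,6-diamino-2,3-dihydroxycyclohexyl in place of 3-((2-aminoethyl)amino)-2-hydroxypropyl on an oxygen on a saturated carbon.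

Among the compounds with values here, the only step that bears on this position is the one in which the side chain on that oxygen is shortened, a number 45.8 percentage points lower from compound 1 to compound 2 (beyond the scatter), a large drop that brought the number down to the low region where compound 3 also sits. The change to compound 4 is of a different kind, a ring with four donors and four acceptors entering for a chain, so that step is a loose guide only; it shows that alteration of this side chain can move the number far. The expected direction for compound 4 is therefore downward, with wide uncertainty, an expected step of a number 28 percentage points lower from compound 1 to compound 4 (beyond the scatter). For compound 4 the estimated value in this assay is 25%, within a range from 5% to 50%.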

Compound 4, a percentage reported as activity, at one concentration (the size of the read-out at that concentration, not a potency): 48.6%
For compound 4 the middle estimate is 23.6 percentage points below the measured one; low and high end bracket the measured number.
By their numbers in this assay, from the lowest: compounds 3 and 2 (each within the scatter of the next); then compounds 4 and 1 (each within the scatter of the next).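

In this assay, exchanging the open chain of compound 1 for 4,6-diamino-2,3-dihydroxycyclohexyl on this oxygen on a saturated carbon gives a number 4.4 percentage points lower from compound 1 to compound 4 (within the scatter), so the high number of compound 1 is not tied to an open chain at this position. Set against the shorter 3-amino-2-hydroxypropyl, the same ring gives a number 41.4 percentage points higher from compound 2 to compound 4 (beyond the scatter), so the low number of compound 2 marks that one side chain and not every change at this oxygen, and the position now shows a large move in both directions. No measurement at hand accounts for either step.

Still open, from the compounds shown here alone, is whether a side chain carrying no amine at all, such as a plain 2,3-dihydroxypropyl, or a longer chain ending in a guanidine, would read with compound 2 or with compound 1 and compound 4 in this assay. Also open, going by these compounds, is what a plain cyclohexyl ring, without its amines and hydroxyl groups, or the same ring with its 5 defined stereocentres inverted, would give on this oxygen.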